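This account rests on a few compounds, and the source may have more. Where it says the series, first, only, none or still open, it means among the compounds named here.

Measured compounds:
- compound 1 `COc1ccc(-c2ccc(Cl)cc2)c(COc2ccc(-c3nc4cc(C(=O)O)ccc4n3C3CCCCC3)cc2)c1`: 24000 nM
- compound 2 `CN(C)S(=O)(=O)c1ccc(-c2ccc(Cl)cc2)c(COc2ccc(-c3nc4cc(C(=O)O)ccc4n3C3CCCCC3)cc2)c1`: 26000 nM

In a functional assay on Huh-5-2 cells (Homo sapiens), read by MTT assay (on this read-out lower numbers stand for higher toxicity in this test and higher numbers for lower toxicity in this test), compound 2 gives 26000 nM, which is level with compound 1 within the scatter. Compound 3 `CC(=O)c1ccc(-c2ccc(Cl)cc2)c(COc2ccc(-c3nc4cc(C(=O)O)ccc4n3C3CCCCC3)cc2)c1` has acetyl in place of dimethylsulfamoyl on an aromatic carbon, para to a 4-chlorophenyl group (acetyl in place of dimethylsulfamoyl on an aromatic carbon). Going by the values given here, the one measured step at this place, a 1.1-fold higher number from compound 1 to compound 2 (0.03 log units; within the scatter), exchanged methoxy for dimethylsulfamoyl and stayed within the scatter. No shift beyond the scatter, in either direction, is therefore expected in this assay. The expected step is a 1.0-fold lower number from compound 2 to compound 3 (0.02 log units; within the scatter). For compound 3 the estimate is 25000 nM, with an expected range of 14000 nM to 42000 nM.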

Compound 3, half-maximal cytotoxic concentration: 24000 nM
Estimate against measurement, compound 3: 1.0-fold (0.02 log units) above; measured number inside the range.
By their numbers in this assay, from the lowest: compounds 1, 3 and 2 (each within the scatter of the next).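

In this assay the change to acetyl gives a 1.1-fold lower number from compound 2 to compound 3 (0.03 log units; within the scatter) and no change at the digits printed from compound 1 to compound 3 (within the scatter) at this aromatic carbon para to a 4-chlorophenyl group. Methoxy, dimethylsulfamoyl and acetyl now all read level here, so the earlier match between two groups extends to a third, one with a carbonyl and no sulfur. No measured evidence bears on why these readings stay level.

Going by these compounds, an amine or a longer chain at this carbon remains open. So does whether any group here can move the reading beyond the scatter.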